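Triazole aryl variation on the shared core: antiproliferative reading

This account rests on a few compounds, and the source may have more. Where it says the series, first, only, none or still open, it means among the compounds named here.

Compound 3 `N#CC1=C(N)Oc2c(c3nc4ccccc4nc3c3ccccc23)C12C(=O)N(Cc1cnnn1-c1ccc(N)cc1)c1ccccc12` carries a 4-aminophenyl on the aromatic nitrogen of the five-membered aromatic ring with 3 nitrogen. In an ADME assay on L02 cells (Homo sapiens) for antiproliferative activity, read by MTT assay, with a stated time of 48 h (a higher number here means a weaker inhibitor, a lower number a stronger inhibitor), compound 3 is reported only as a limit of the assay, > 50000 nM. Compound 1 `N#CC1=C(N)Oc2c(c3nc4ccccc4nc3c3ccccc23)C12C(=O)N(Cc1cnnn1-c1ccc(Cl)cc1)c1ccccc12`, bearing chloro on the aromatic carbon instead, also gives only a limit in this assay, > 50000 nM. Compound 2 `COc1ccc(-n2nncc2CN2C(=O)C3(C(C#N)=C(N)Oc4c3c3nc5ccccc5nc3c3ccccc43)c3ccccc32)cc1`, with methoxy on that aromatic carbon, is likewise reported as a limit, > 50000 nM. The three steps among them, a step that the two limits leave unreadable from compound 1 to compound 2, a step that the two limits leave unreadable from compound 1 to compound 3 and a step that the two limits leave unreadable from compound 2 to compound 3, are therefore unreadable in size and direction; what the numbers show is the limit of > 50000 nM in this assay, at which 3 of the 3 values shown sit.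

Compound 4 `Cc1ccc(C)c(-n2nncc2CN2C(=O)C3(C(C#N)=C(N)Oc4c3c3nc5ccccc5nc3c3ccccc43)c3ccccc32)c1` is the next member: 2,5-dimethylphenyl in place of 4-aminophenyl on an aromatic nitrogen. Among the measured compounds shown here, no measured step covers this exchange. Chloro, methoxy and amino on the aryl have all left the series at the limit, so no step beyond the scatter is expected in this assay, and the likeliest outcome for compound 4 is once more a limit. Compound 4 is expected at 60000 nM, within a range of 20000 nM to 200000 nM. The expected step that the limit leaves unreadable from compound 3 to compound 4 is accordingly essentially flat.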

Compound 4, half-maximal inhibitory concentration: > 50000 nM
Compound 4: a limit, no number; the forecaster's own chance of this, stated with the estimate: 85%; the middle value does not contradict the limit.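

Compound 4 is also reported only as a limit in this assay, > 50000 nM. No step from compound 1, compound 2 or compound 3 to compound 4 can be read, since every value is a limit: the limit of > 50000 nM in this assay, at which 4 of the 4 values shown sit.

The compounds shown leave open how these four aryl groups rank against one another in this assay.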